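From furan-2-yl to pyridin-2-yl: notes on compound 4

This account rests on a few compounds, and the source may have more. Where it says the series, first, only, none or still open, it means among the compounds named here.

In a functional assay on MGC-803 cells (Homo sapiens) for cytotoxicity, read by MTT assay, with a stated time of 38 h (on this read-out lower numbers stand for stronger inhibition and higher numbers for weaker inhibition), compound 1 (`COc1cc(OC)c2c(=O)c(OCC(=O)N/N=C/c3ccccc3F)c(-c3cc(OC)c(OC)c(OC)c3)oc2c1`) gives 2780 nM, compound 2 (`COc1cc(OC)c2c(=O)c(OCCCCN3CCN(C)CC3)c(-c3cc(OC)c(OC)c(OC)c3)oc2c1`) gives 12200 nM and compound 3 (`COc1cc(OC)c2c(=O)c(OCC(=O)N/N=C/c3ccco3)c(-c3cc(OC)c(OC)c(OC)c3)oc2c1`) gives 6050 nM. Compound 3 stands with compound 2 at the higher end of these numbers, as a 2.0-fold lower number from compound 2 to compound 3 (0.30 log units; within the scatter) shows, and apart from compound 1, as a 2.2-fold higher number from compound 1 to compound 3 (0.34 log units; beyond the scatter) shows. Compound 4 (`COc1cc(OC)c2c(=O)c(OCC(=O)N/N=C/c3ccccn3)c(-c3cc(OC)c(OC)c(OC)c3)oc2c1`) carries pyridin-2-yl in place of furan-2-yl on a carbon with a double bond to nitrogen. Only the modest step to compound 3 from compound 1 changes that same carbon. The step of a 4.4-fold higher number from compound 1 to compound 2 (0.64 log units; beyond the scatter) alters a larger group and bears less. Going by the values given here, no pyridin-2-yl compound has been measured, so no firm direction follows. The estimated step, a 1.5-fold lower number from compound 3 to compound 4 (0.18 log units; within the scatter), is not expected to exceed the scatter. Compound 4 is expected at 4000 nM, within an estimated range of 1500 nM to 11000 nM.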

Compound 4, half-maximal inhibitory concentration: 15300 nM
Compound 4: the middle estimate sits 3.8-fold (0.58 log units) below what was measured; measured number above the stated range.
By their numbers in this assay, from the lowest: compound 1; then compounds 3, 2 and 4 (each within the scatter of the next, the first and the last beyond it).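

Going by these compounds alone, on the carbon with a double bond to nitrogen, the choice of ring carries more weight in this assay than the earlier compounds showed: pyridin-2-yl gives a 2.5-fold higher number from compound 3 to compound 4 (0.40 log units; beyond the scatter) and a 5.5-fold higher number from compound 1 to compound 4 (0.74 log units; beyond the scatter), so 2-fluorophenyl, furan-2-yl and pyridin-2-yl separate in that order. Exchanging the larger group gives a 1.3-fold higher number from compound 2 to compound 4 (0.10 log units; within the scatter), with no separation between those two compounds. No evidence on the cause of these steps is at hand. As far as these compounds go, whether plain phenyl or thiophen-2-yl at this carbon would stand nearer compound 1 or compound 4 remains open.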